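A few compounds are considered here, and "the series" means these few. Any claim that something is new, unique, unknown or untested is made for them only; others in the source may bear on it.

In a functional assay on HCT-116 cells (Homo sapiens) for inhibition, read by MTT assay, with a stated time of 72 h (on this read-out higher numbers stand for weaker inhibition and lower numbers for stronger inhibition), compound 1 (`CNC(=O)CCCCCCCn1nc(-c2cnc3[nH]ccc3c2)c2c(N)ncnc21`) gives 6760 nM as its reading. For compound 2 (`Nc1ncnc2c1c(-c1cnc3[nH]ccc3c1)nn2CCCCC(=O)NO`) the reading is a limit and not a number, with > 150000 nM being all that is reported. Going by the values given here, the one measured step is an at least 22-fold higher number from compound 1 to compound 2 (1.34 log units; beyond the scatter) and it alters the end of the chain, not the aromatic group at issue here, so it gives no direct measure of the change that follows. Compound 3 (`Nc1nc2cc(-c3nn(CCCCCCCCCC(=O)NO)c4ncnc(N)c34)ccc2o1`) gives 23100 nM as the highest of the true numbers, a higher reading than compound 1 at 6760 nM and one beyond the scatter. The change to compound 4 (`Nc1ncnc2c1c(-c1cnc3[nH]ccc3c1)nn2CCCCCCCCCC(=O)NO`) is a group of 9 heavy atoms (7 carbon, 2 nitrogen; one five-membered aromatic ring with 1 hetero atom, one six-membered aromatic ring with 1 hetero atom) in place of a group of 10 heavy atoms (7 carbon, 2 nitrogen, 1 oxygen; one five-membered aromatic ring with 2 hetero atoms, one six-membered aromatic ring of carbon only), on an aromatic carbon on that carbon, and the chain of compound 3 stays. Among the compounds with values here, the entering group is the one carried by compound 1, which gives 6760 nM with it, so a modest shift towards a lower number is expected. The expected move is a 1.9-fold lower number from compound 3 to compound 4 (0.28 log units; within the scatter) and it may not clear the scatter. For compound 4 the estimate is 12000 nM with an expected range from 2500 nM up to 60000 nM in this assay as the likely outcome.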

Compound 4, half-maximal inhibitory concentration: 18700 nM
Compound 4: middle estimate off by 1.6-fold (0.19 log units), on the low side; the measured number falls inside the stated range.
By their numbers in this assay, from the lowest: compound 1; then compounds 4 and 3 (each within the scatter of the next). At a limit, above all of these: compound 2.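

In this assay, putting the group carried by compound 1 in place of 2-amino-1,3-benzoxazol-5-yl on this aromatic carbon, with the chain held, gives a step that does not clear the scatter: a 1.2-fold lower number from compound 3 to compound 4 (0.09 log units; within the scatter). Compound 2 gives a limit and not a number: the limit of > 150000 nM in this assay, at which 1 of the 4 values shown sits. With the aromatic group held, an at least 8.0-fold lower number from compound 2 to compound 4 (0.90 log units; beyond the scatter) comes with 5-(hydroxycarbamoyl)pentyl in place of hydroxycarbamoyl, and a 2.8-fold higher number from compound 1 to compound 4 (0.44 log units; beyond the scatter) comes with 2-(hydroxycarbamoyl)ethyl in place of methylcarbamoyl, so among these compounds the changes at the chain end clear the scatter while this aromatic exchange does not.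

The compounds shown leave open whether a simple phenyl ring at this position would read any differently. They also leave open how a carboxylic acid at the chain end would compare with hydroxycarbamoyl.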